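This account rests on a few compounds, and the source may have more. Where it says the series, first, only, none or still open, it means among the compounds named here.

Compound 1 `CCNc1[nH]c(=O)n(O)c(=O)c1C(=O)NCc1ccccc1`: 83.9%
Compound 2 `CCNc1[nH]c(=O)n(O)c(=O)c1C(=O)NCc1cccc(Cl)c1F`: 94%
Compound 3 `CCNc1[nH]c(=O)n(O)c(=O)c1C(=O)NCc1ccc(F)cc1`: 86.5%

In an ADME assay on a cell-free system (plasma, Mus musculus) for protein binding, compound 3 gives 86.5%. That places it level with compound 1, a 1.2-fold lower unbound fraction from compound 1 to compound 3 (0.08 log units; within the scatter), and apart from compound 2, a 2.3-fold higher unbound fraction from compound 2 to compound 3 (0.35 log units; beyond the scatter).

Compound 4 `CCNc1[nH]c(=O)n(O)c(=O)c1C(=O)NCc1ccc(C)c(F)c1` has not been measured. It differs from compound 3 by one change: 3-fluoro-4-methylphenyl in place of 4-fluorophenyl on a saturated chain carbon bound to an amide-type nitrogen. Here 3-fluoro-4-methylphenyl takes the place of 4-fluorophenyl on a saturated chain carbon bound to an amide-type nitrogen.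

Going by the values given here, two measured steps bear on this. Fluoro in place of hydrogen on the aromatic ring gave a 1.2-fold lower unbound fraction from compound 1 to compound 3 (0.08 log units; within the scatter). The 3-chloro-2-fluorophenyl in place of phenyl gave a larger step, a 2.7-fold lower unbound fraction from compound 1 to compound 2 (0.43 log units; beyond the scatter). Among the compounds with values here, no measured step shows the effect of a methyl group. The change is therefore expected to be small, towards a lower unbound fraction, and probably within the scatter.

The expected step is a 1.4-fold lower unbound fraction from compound 3 to compound 4 (0.13 log units; within the scatter). For compound 4 the estimate is 90%, with an expected range of 85% to 94%.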

Compound 4, plasma protein binding: 95.9%
Estimate against measurement, compound 4: 2.4-fold (0.39 log units) (unbound fraction) above, and the stated range ends below it.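

In this assay, the aryl group on the saturated chain carbon bound to an amide-type nitrogen proved more responsive than the fluoro step alone had suggested: 3-fluoro-4-methylphenyl in place of 4-fluorophenyl gave a clear step (a 3.3-fold lower unbound fraction from compound 3 to compound 4 (0.52 log units; beyond the scatter)), and the step from phenyl was similar in kind (a 3.9-fold lower unbound fraction from compound 1 to compound 4 (0.59 log units; beyond the scatter)). A group without chlorine also stands level with 3-chloro-2-fluorophenyl (a 1.5-fold lower unbound fraction from compound 2 to compound 4 (0.17 log units; within the scatter)), so compound 2 and compound 4 together sit apart from compound 1 and compound 3. Nothing available explains these steps.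

Going by these compounds, whether the methyl alone or its combination with the fluoro carries the step remains open. So does the effect of an amine or a carboxylic acid on this ring.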